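Sulfonyl aryl swap, bromo to fluoro, compound 2 to 4

The source may hold more compounds than are shown below. What is called first, only, known or untested is meant among the compounds shown, and "the series" means these compounds.

For the measured compounds named here, compound 2 `O=S(=O)(NCCNc1nccc(-c2c(-c3cccc(F)c3)nc3sccn23)n1)c1ccc(Br)cc1` gives 13500 nM in a functional assay on A-375 cells (Homo sapiens) for cytotoxicity, read by MTT assay (on this read-out lower numbers stand for stronger inhibition and higher numbers for weaker inhibition), and stands second highest of the three numbers so far. Compound 3 `Cc1ccc(S(=O)(=O)NCCNc2nccc(-c3c(-c4cccc(F)c4)nc4sccn34)n2)cc1` lies nearest with 15400 nM in this assay, and compound 1 `O=S(=O)(NCCCNc1nccc(-c2c(-c3cccc(F)c3)nc3sccn23)n1)c1ccc(Br)cc1` furthest with 7040 nM in this assay; both gaps sit within the scatter. The chain steps a 1.9-fold higher number from compound 1 to compound 2 (0.28 log units; within the scatter) and a 2.2-fold higher number from compound 1 to compound 3 (0.34 log units; beyond the scatter) stay small. Compound 4 `O=S(=O)(NCCNc1nccc(-c2c(-c3cccc(F)c3)nc3sccn23)n1)c1cccc(F)c1` differs from compound 2 by 3-fluorophenyl in place of 4-bromophenyl on a sulfonyl sulfur. The step bearing on this is a 1.1-fold higher number from compound 2 to compound 3 (0.06 log units; within the scatter), a change on an aromatic carbon of the same sulfonyl aryl that stayed within the scatter, so no step beyond the scatter is expected in this assay. Compound 4 is therefore estimated at 14000 nM, range 6000 nM to 32000 nM, meaning an expected 1.0-fold higher number from compound 2 to compound 4 (0.02 log units; within the scatter).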

Compound 4, half-maximal inhibitory concentration: 14900 nM
Compound 4: the middle estimate sits 1.1-fold (0.03 log units) below what was measured, and the stated range covers the measured number.
By their numbers in this assay, from the lowest: compounds 1, 2, 4 and 3 (each within the scatter of the next, the first and the last beyond it).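

Across this assay, moving from a 4-substituted aryl to 3-fluorophenyl on the sulfonyl sulfur gives a step within the scatter (a 1.1-fold higher number from compound 2 to compound 4 (0.04 log units; within the scatter)). The comparison with 4-methylphenyl is also within the scatter (a 1.0-fold lower number from compound 3 to compound 4 (0.01 log units; within the scatter)), so the three aryl groups on this chain cannot be ordered. The step beyond the scatter (a 2.1-fold higher number from compound 1 to compound 4 (0.33 log units; beyond the scatter)) combines the chain and aryl changes, so neither can be read alone.

No measurement here offers a reason for this flat response. From the compounds shown here alone, whether an amine or carboxylic acid on the aryl ring, or a longer chain, would shift the number remains open.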